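The source may report more compounds than this note shows. Statements on the series, on what has been measured and on what is new or still open speak of the compounds shown alone.

Among the compounds with values here, compound 3 `Cc1cc(NC(=O)CC2CCCCC2)nn1Cc1cc(Cl)ccc1OCc1ccccc1` gives 3.2 in a physicochemical assay for lipophilicity, at pH 7.4 (a lower number here means a more polar compound, a higher number a more lipophilic compound), the only true number so far. Compound 1 `CNC(=O)c1cc(C)n(Cc2cc(Cl)ccc2OCc2ccccc2)n1` gives > 3.7, which is a limit and not a number. Compound 2 `Cc1cc(C(=O)NC(C)C)nn1Cc1cc(Cl)ccc1OCc1ccccc1` gives > 3.7, which is also a limit. Between these two limits there is a step that the two limits leave unreadable from compound 1 to compound 2. Putting ((cyclohexylmethyl)carbonyl)amino in place of methylcarbamoyl gives a number at least 0.50 log units lower from compound 1 to compound 3 (beyond the scatter). Putting the same group in place of isopropylcarbamoyl gives a number at least 0.50 log units lower from compound 2 to compound 3 (beyond the scatter). Compound 3 therefore stands lowest of the three in this assay.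

Compound 4 `Cc1cc(NC(=O)OC(C)(C)C)nn1Cc1cc(Cl)ccc1OCc1ccccc1` has not been measured. It carries tert-butoxy in place of cyclohexylmethyl on a carbonyl carbon. The two steps into compound 3 act at the same place, cut one bond further out, but neither exchanges these two groups and each starts from a limit, so neither fixes a size for this change. Compound 4 keeps the amide-type nitrogen on that carbonyl carbon, so the best anchor is compound 3 at 3.2. No change beyond the scatter is expected, and the expected shift is a number 0.10 log units higher from compound 3 to compound 4 (within the scatter). The estimate for compound 4 is 3.3, with an expected range from 2.8 to 3.8.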

Compound 4, distribution coefficient: > 3.7
Compound 4: a limit, no number; the forecaster's own chance of this, stated with the estimate: 20%; at least 0.40 log units between middle value and limit.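

Tert-butoxy in place of cyclohexylmethyl on a carbonyl carbon gives a number at least 0.50 log units higher from compound 3 to compound 4 (beyond the scatter) in this assay. Compound 4 gives > 3.7, which is a limit and not a number. The earlier steps shown here into compound 3 replaced methylcarbamoyl or isopropylcarbamoyl on an aromatic carbon, so they could not separate the amino-linked carbonyl from the group it carries; compound 4 keeps that amide-type nitrogen on the carbonyl carbon and still sits beyond the scatter from compound 3, so the lower reading of compound 3 does not follow from the amino-linked carbonyl alone.

From the compounds shown here alone, the steps from compound 1 and from compound 2 to compound 4 cannot be read, and the full size of the step into compound 4 stays open, as the readings of three compounds end at the same ceiling: the limit of > 3.7 in this assay, at which 3 of the 4 values shown sit. Also open, going by these compounds, is where methoxy, dimethylamino or a longer chain on this carbonyl carbon would fall, and whether any of them would give a true number rather than a limit.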